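Aryl swaps on the shared core: compound 2 to compound 4

This account rests on a few compounds, and the source may have more. Where it says the series, first, only, none or still open, it means among the compounds named here.

Measured in a functional assay on SGC-7901 cells (Homo sapiens) for inhibition, read by MTT assay, with a stated time of 24 h; a lower number here means a stronger inhibitor, a higher number a weaker inhibitor
- compound 1 `CC1(C)[C@H]2CC[C@]1(C)N(Cc1cn(-c3cccc(F)c3)nn1)C(=O)C2` gives 530 nM
- compound 2 `CC1(C)[C@H]2CC[C@]1(C)N(Cc1cn(-c3cccc(C#N)c3)nn1)C(=O)C2` gives 250 nM
- compound 3 `CC1(C)[C@H]2CC[C@]1(C)N(Cc1cn(-c3ccccc3Cl)nn1)C(=O)C2` gives 220 nM

Compound 2 stands within the scatter of compound 3, as a 1.1-fold lower number from compound 2 to compound 3 (0.06 log units; within the scatter) shows, and well clear of compound 1, with a 2.1-fold lower number from compound 1 to compound 2 (0.33 log units; beyond the scatter) beyond the scatter. Compound 4 `COc1ccccc1-n1cc(CN2C(=O)C[C@@H]3CC[C@@]2(C)C3(C)C)nn1` is the next case, with 2-methoxyphenyl in place of 3-cyanophenyl on an aromatic nitrogen. For the measured compounds named here, no measured compound carries 2-methoxyphenyl, so the guide is limited to the aryl swaps already seen. These are small: a 2.4-fold lower number from compound 1 to compound 3 (0.38 log units; beyond the scatter) is modest, and the swap from 3-cyanophenyl to 2-chlorophenyl, a 1.1-fold lower number from compound 2 to compound 3 (0.06 log units; within the scatter), stays within the scatter. Going by the values given here, that last swap is the closest precedent, since compound 3 also carries a 2-substituted phenyl. No step beyond the scatter is therefore expected in this assay, and no direction can be favoured. The estimated step is a 1.0-fold higher number from compound 2 to compound 4 (0.02 log units; within the scatter). Compound 4 is expected at about 260 nM, within an estimated range of 110 nM to 600 nM.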

Compound 4, half-maximal inhibitory concentration: 280 nM
Compound 4: the middle estimate sits 1.1-fold (0.03 log units) below what was measured; measured number inside the range.
By their numbers in this assay, from the lowest: compounds 3, 2, 4 and 1 (each within the scatter of the next, the first and the last beyond it).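

In this assay 2-methoxyphenyl on the aromatic nitrogen cannot be separated from 3-cyanophenyl (a 1.1-fold higher number from compound 2 to compound 4 (0.05 log units; within the scatter)), and methoxy in place of chloro on an aromatic carbon also leaves the number unresolved (a 1.3-fold higher number from compound 3 to compound 4 (0.10 log units; within the scatter)). Compound 4 also stays within the scatter of the 3-fluorophenyl compound (a 1.9-fold lower number from compound 1 to compound 4 (0.28 log units; within the scatter)), so it falls on neither side of the gap that separates compound 1 from compounds 2 and 3. Nothing available explains how close these aryl groups lie.

Whether one substituent reads the same in the 2- and 3-positions of the phenyl ring remains open, as the compounds shown offer no such pair. Also open, going by these compounds, is how an amine, a carboxylic acid or a longer alkoxy chain on this phenyl ring would read.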